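This account rests on a few compounds, and the source may have more. Where it says the series, first, only, none or still open, it means among the compounds named here.

In a functional assay on SMMC-7721 cells (Homo sapiens) for cytotoxicity, read by MTT assay, with a stated time of 72 h (a higher number here means a weaker inhibitor, a lower number a stronger inhibitor), compound 1 `COc1cccc(C=C2C(=O)N(c3ccc(Cl)cc3)N(c3ccc(Cl)cc3)C2=O)c1` gives 30200 nM, while compound 2 `COc1cccc(C=C2C(=O)N(c3ccc(Cl)cc3)N(c3ccc(Cl)cc3)C2=O)c1OC` gives 14100 nM, the lower of the two numbers. Compound 3 `O=C1C(=Cc2ccc(Cl)cc2Cl)C(=O)N(c2ccc(Cl)cc2)N1c1ccc(Cl)cc1` differs from compound 2 in one place: 2,4-dichlorophenyl in place of 2,3-dimethoxyphenyl on a double-bonded chain carbon bound to a double-bonded ring carbon. For the measured compounds named here, the only measured step, a 2.1-fold lower number from compound 1 to compound 2 (0.33 log units; beyond the scatter), is modest and concerns methoxy in place of hydrogen on an aromatic carbon, so it offers only loose guidance for this larger swap. A similarly modest move is expected, slightly downward if anything, and this estimated step is a 1.2-fold lower number from compound 2 to compound 3 (0.07 log units; within the scatter). The estimate for compound 3 is 12000 nM, with an expected range of 4000 nM to 35000 nM.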

Compound 3, half-maximal inhibitory concentration: > 128000 nM
Compound 3 was reported as a limit; the forecaster's own chance of this, stated with the estimate: 5%; at least 10-fold (1.02 log units) between middle value and limit.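

Compound 3 is reported as a limit and not a number: the limit of > 128000 nM in this assay, at which 1 of the 3 values shown sits. The aromatic group on this double-bonded chain carbon can therefore matter more than the methoxy step suggested, and the change here weakens the compound: 2,4-dichlorophenyl in place of 2,3-dimethoxyphenyl gives an at least 9.0-fold higher number from compound 2 to compound 3 (0.95 log units; beyond the scatter), and in place of 3-methoxyphenyl it gives an at least 4.2-fold higher number from compound 1 to compound 3 (0.62 log units; beyond the scatter).

Each swap removes methoxy and adds chlorine together, so the two changes cannot be separated here. As far as these compounds go, whether a phenyl ring carrying a single chlorine or an amine would behave like compound 2 or compound 3 remains open.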